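The compounds below may be only part of what the source reports. "The series", "measured", "known", "first", "only" and "open" are said of these compounds alone.

Measured so far in an ADME assay (liver) for metabolic stability, with Liver microsome (Homo sapiens) as the target, using microsomes and NADPH, with a stated time of 30 min, tested at 1 uM; a higher number here means faster removal of the compound, a lower number slower removal
Compound 1 `COc1cc(C(O)(C(F)(F)F)C(F)(F)F)cnc1N1CCN(S(=O)(=O)c2ccc(N)nc2)CC1` gives < 14 mL.min-1.g-1 as a limit
Compound 2 `CC(C)(O)C#Cc1cc(C(O)(C(F)(F)F)C(F)(F)F)cnc1N1CCN(S(=O)(=O)c2ccc(N)nc2)CC1` gives < 14 mL.min-1.g-1 as a limit
Compound 3 `Nc1ccc(S(=O)(=O)N2CCN(c3ncc(C(O)(C(F)(F)F)C(F)(F)F)cc3C#CCCO)CC2)cn1` gives < 14 mL.min-1.g-1 as a limit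

Compound 3 has a limit and no number, and the series as a whole shows the limit of < 14 mL.min-1.g-1 in this assay, at which 3 of the 3 values shown sit, with no exception. Compound 4 `CC(C)(C)n1cc(-c2cc(C(O)(C(F)(F)F)C(F)(F)F)cnc2N2CCN(S(=O)(=O)c3ccc(N)nc3)CC2)cn1` carries 1-(tert-butyl)-1H-pyrazol-4-yl in place of 4-hydroxybut-1-yn-1-yl on an aromatic carbon, and the change counts as 1-(tert-butyl)-1H-pyrazol-4-yl in place of 4-hydroxybut-1-yn-1-yl on an aromatic carbon in full. The steps at this place are a step that the two limits leave unreadable from compound 1 to compound 3 and a step that the two limits leave unreadable from compound 2 to compound 3 and neither gives a size to carry over. For the measured compounds named here, no measured compound has a ring at this place. Compound 3 sits at the limit < 14 mL.min-1.g-1 so any readable step could only run upward, and another limit remains quite possible. The expected step is an at least 1.4-fold higher number from compound 3 to compound 4 (0.15 log units; that floor lies within the scatter) as a modest rise. For compound 4 the estimated value is 20 mL.min-1.g-1 as the working figure. The expected range runs from 10 mL.min-1.g-1 to 50 mL.min-1.g-1 for this estimate.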

Compound 4, intrinsic clearance in microsomes: 86 mL.min-1.g-1
Estimate against measurement, compound 4: 4.3-fold (0.63 log units) below; measured number outside the range, above it.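

In this assay, this position can clearly move the read-out: 1-(tert-butyl)-1H-pyrazol-4-yl gives an at least 6.1-fold higher number from compound 3 to compound 4 (0.78 log units; beyond the scatter), an at least 6.1-fold higher number from compound 2 to compound 4 (0.78 log units; beyond the scatter) and an at least 6.1-fold higher number from compound 1 to compound 4 (0.78 log units; beyond the scatter). For the compounds shown here, the steps among compound 1, compound 2 and compound 3 cannot be read, so these are the only sized changes at this position. Compound 4 is the only compound shown that stands clear of the limit: the limit of < 14 mL.min-1.g-1 in this assay, at which 3 of the 4 values shown sit.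

The compounds shown leave open whether the rise goes with the aromatic ring itself or with the tert-butyl on it. A 1-methyl-1H-pyrazol-4-yl at this place would separate the two.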